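A few compounds are considered here, and "the series" means these few. Any claim that something is new, unique, unknown or untested is made for them only; others in the source may bear on it.

Compound 1 `Cc1ccc(S(=O)(=O)Nc2ccc(-c3nc4ccccc4o3)cc2)cc1` gives > 63000 nM in an assay on isolated protein for inhibition of malate dehydrogenase, mitochondrial (Sus scrofa), with stated times of 45 min and 30 min (on this read-out higher numbers stand for weaker inhibition and lower numbers for stronger inhibition), which is a limit of the assay and not a number.
Compound 2 `COc1cccc(S(=O)(=O)Nc2ccc3oc(-c4ccccc4)nc3c2)c1` gives > 63000 nM in this assay, again only a limit.
Compound 3 `O=S(=O)(Nc1ccc(-c2nc3ccccc3o2)cc1)c1ccc(C(F)(F)F)cc1` gives > 63000 nM in this assay, once more a limit.

Compound 1 therefore stands at the limit, and so do the other two compounds: the limit of > 63000 nM in this assay, at which 3 of the 3 values shown sit. Among the measured compounds shown here, the one measured step that changes a single place, a step that the two limits leave unreadable from compound 1 to compound 3, trifluoromethyl in place of methyl on an aromatic carbon, has limits at both ends, so its size cannot be read. Compound 2 and compound 1 differ in more than one place, and both show only a limit.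

Compound 4 `O=S(=O)(Nc1ccc(-c2nc3ccccc3o2)cc1)c1ccc(Cl)c(Cl)c1` differs from compound 1 by 3,4-dichlorophenyl in place of 4-methylphenyl on a sulfonyl sulfur. The measured step from compound 1 to compound 3 is the only one that bears on this change, and it is unreadable. For the measured compounds named here, no measured step shows a move beyond the scatter, so no such move is expected here. Compound 4 is expected to give about 80000 nM, with a range from 40000 nM to 200000 nM, and most likely only a limit again. The step this estimate means, a step that the limit leaves unreadable from compound 1 to compound 4, is expected to stay within the scatter.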

Compound 4, half-maximal inhibitory concentration: > 63000 nM
Compound 4: only a limit was reported; the forecaster's own chance of this, stated with the estimate: 85%; the middle value lies beyond the limit too.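

Compound 4, like compound 1, shows only a limit, so the step between compound 1 and compound 4 cannot be read and this result gives no new step: the limit of > 63000 nM in this assay, at which 4 of the 4 values shown sit.

The compounds shown leave open how the four compare with one another in this assay, and which change, if any, would yield a readable value there.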